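Moving a chlorine on a weakly active compound

The source may hold more compounds than are shown below. What is called first, only, known or untested is meant among the compounds shown, and "the series" means these compounds.

Compound 1 `O=C1N/C(=N\Cc2ccccc2)S/C1=C1/CCNC(=O)c2[nH]ccc21`: 49700 nM
Compound 2 `O=C1N/C(=N\Cc2ccc(Cl)cc2)S/C1=C1/CCNC(=O)c2[nH]ccc21`: > 100000 nM, a limit and not a number

In a functional assay on HCT-116 cells (Homo sapiens) for inhibition, read by MTT assay, with a stated time of 48 h (a lower number here means a stronger inhibitor, a higher number a weaker inhibitor), compound 2 stands at the limit of > 100000 nM in this assay, at which 1 of the 2 values shown sits. Compound 3 `O=C1N/C(=N\Cc2ccccc2Cl)S/C1=C1/CCNC(=O)c2[nH]ccc21` has 2-chlorophenyl in place of 4-chlorophenyl on a saturated chain carbon bound to a double-bonded nitrogen. Going by the values given here, one measured step bears on this change: an at least 2.0-fold higher number from compound 1 to compound 2 (0.30 log units; that floor lies within the scatter), where chloro replaced hydrogen on an aromatic carbon. That step adds a chlorine rather than moving one, so no step beyond the scatter is expected in this assay. The estimated step is an at least 1.2-fold lower number from compound 2 to compound 3 (0.09 log units; that floor lies within the scatter). For compound 3 the expected value is 80000 nM, within an estimated range of 40000 nM to 160000 nM.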

Compound 3, half-maximal inhibitory concentration: > 50000 nM
Compound 3: no number, only a limit; the forecaster's own chance of this, stated with the estimate: 50%; the middle value lies beyond the limit too.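

In this assay compound 3 gives > 50000 nM, which is a limit and not a number. Compound 2 gives > 100000 nM, also a limit and not a number. Going by these compounds alone, the one step that can be read is a number no lower from compound 1 to compound 3 (the limit leaves the size open). The step from compound 2 to compound 3 cannot be read, so 2-chlorobenzyl gains no measured place relative to 4-chlorobenzyl.

From the compounds shown here alone, whether the place of the chlorine matters at all stays open. So does how an amine or a carboxylic acid in place of the chlorine would read.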